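The source may hold more compounds than are shown below. What is called first, only, known or untested is meant among the compounds shown, and "the series" means these compounds.

Measured in an ADME assay on S9 fraction from liver (Rattus norvegicus) for metabolic stability, with a stated time of 1 h; on this read-out higher numbers stand for a more stable compound and lower numbers for a less stable compound:
- Compound 1 `N#Cc1cnc(NCc2cnccc2C(F)(F)F)cc1N[C@H]1C[C@@H](O)C1`: 70%
- Compound 2 `CO[C@H]1CC[C@@H](Nc2cc(NCc3cnccc3C(F)(F)F)ncc2C#N)CC1`: 1%
- Compound 3 `N#Cc1cnc(NCc2cnccc2C(F)(F)F)cc1NC1CCOCC1`: 17%

Compound 3 stands second highest of these three, with compound 2 lower and compound 1 higher. Unmeasured compound 4 `N#Cc1cnc(NCc2cnccc2C(F)(F)F)cc1N[C@H]1CC[C@@H](C(N)=O)CC1` differs from it in one place: 4-carbamoylcyclohexyl in place of oxan-4-yl on a nitrogen on an aromatic ring. In words, this is 4-carbamoylcyclohexyl in place of oxan-4-yl on a nitrogen on an aromatic ring.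

Three measured steps changed this same place. The step of a number 16 percentage points higher from compound 2 to compound 3 (beyond the scatter) is modest, while a number 69 percentage points lower from compound 1 to compound 2 (beyond the scatter) and a number 53 percentage points lower from compound 1 to compound 3 (beyond the scatter) are large. Such swings make any forecast uncertain. The cyclohexyl ring of compound 4 recalls compound 2 at 1%, while its hydrogen-bond donor recalls the hydroxy group of compound 1 at 70%. A moderate rise is therefore expected, estimated as a number 23 percentage points higher from compound 3 to compound 4 (beyond the scatter). For compound 4 the estimated value is 40%, with an expected range of 12% to 72%.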

Compound 4, percent of the compound remaining: 30%
Compound 4: middle estimate off by 10 percentage points, on the high side, and the stated range covers the measured number.
By their numbers in this assay, from the lowest: compound 2; then compound 3; then compound 4; then compound 1.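

In this assay, 4-carbamoylcyclohexyl in place of oxan-4-yl gives a modest gain (a number 13 percentage points higher from compound 3 to compound 4 (beyond the scatter)), so this nitrogen can carry the larger group without a loss in stability. Carbamoyl in place of methoxy on a saturated ring carbon also raises the number (a number 29 percentage points higher from compound 2 to compound 4 (beyond the scatter)), showing that the substituent on the cyclohexyl ring matters, not the ring alone. Even so, 3-hydroxycyclobutyl remains clearly ahead (a number 40 percentage points lower from compound 1 to compound 4 (beyond the scatter)).

Nothing available explains these differences. Still open, on these data alone, is how a hydroxy group, an amine or a carboxylic acid on the cyclohexyl ring would compare with carbamoyl.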